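Chain-length series on a bromo and a des-bromo acetophenone core

The source may hold more compounds than are shown below. What is called first, only, known or untested is meant among the compounds shown, and "the series" means these compounds.

Compound 1 `CCCCCCCCCCCCCCOc1cc(OC)c(Br)cc1C(C)=O` and compound 2 `CCCCCCCCCCCCCCCCOc1cc(OC)c(Br)cc1C(C)=O` share one core and differ only in the length of the alkoxy chain. In a functional assay, with a stated time of 30 min (a higher number here means a weaker inhibitor, a lower number a stronger inhibitor), compound 1 gives 16100000 nM, and compound 2 gives 6500000 nM. The change between them is ethyl in place of hydrogen on a saturated chain carbon, ten or more bonds along the chain from an oxygen on an aromatic ring, and it produced a 2.5-fold lower number from compound 1 to compound 2 (0.39 log units; beyond the scatter).

Compound 3 `CCCCCCOc1cc(OC)ccc1C(C)=O` is built on a second core; the difference between the two cores is not broken down here. In this assay compound 3 gives 42600000 nM, the highest number of the three measured compounds, with compound 1 the nearest of them.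

Compound 4 `CCCCCCCCOc1cc(OC)ccc1C(C)=O` is not yet measured. It relates to compound 3 through (ethyl in place of hydrogen on a saturated chain carbon, six bonds along the chain from an oxygen on an aromatic ring). Among the compounds with values here, this is the same kind of change as the one from compound 1 to compound 2, but not the same: the ethyl enters at a different place along the chain, and the cores differ.

Within the data shown here, the expectation rests on the measured step from compound 1 to compound 2, which was a 2.5-fold lower number from compound 1 to compound 2 (0.39 log units; beyond the scatter); a step of similar size, a 2.7-fold lower number from compound 3 to compound 4 (0.43 log units; beyond the scatter), is expected here, although only one prior example exists and it sits on a different core. Compound 4 is therefore estimated at 16000000 nM in this assay, with a plausible range from 6000000 nM to 36000000 nM.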

Compound 4, half-maximal inhibitory concentration: 40000000 nM
The estimate for compound 4 lay 2.5-fold (0.40 log units) below the measured number; measured number outside the range, above it.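

In this assay the added ethyl gives a 1.1-fold lower number from compound 3 to compound 4 (0.03 log units; within the scatter), and on this core that step cannot be told apart from no change at all. Set beside the earlier step, it does not establish that the two cores respond differently, even though only the earlier step clears the scatter: the same change on two cores in this assay, a 2.5-fold lower number (0.39 log units; beyond the scatter) from compound 1 to compound 2 and a 1.1-fold lower number (0.03 log units; within the scatter) from compound 3 to compound 4, 2.3-fold (0.37 log units) apart, within the scatter of two such steps. With one pair per core, and the ethyl entering at a different place along the chain in each pair, these results neither confirm that the change carries from one core to the other nor show that it fails to, so any gain from extending the chain remains specific to the pair in which it was seen.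

On these data alone, what the bromine contributes on its own stays open, as the comparison between the two cores is not broken down in these compounds. Also open, as far as these compounds go, is whether a longer chain on the core of compound 3 would produce a step beyond the scatter, and whether an amine or a carboxylic acid in place of the entering ethyl would move the number in either series.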